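The compounds below may be only part of what the source reports. "The series", "measured", "known", "first", "only" and "open" are said of these compounds alone.

In a functional assay on HL-60 cells (Homo sapiens) for inhibition, read by CCK-8 assay, with a stated time of 48 h (a higher number here means a weaker inhibitor, a lower number a stronger inhibitor), compound 1 `O=C(Nc1cccc([N+](=O)[O-])c1)N1CCN(S(=O)(=O)c2sccc2-c2ccccc2Oc2ccc(O)c(O)c2)CC1` gives 4500 nM. Compound 2 `COc1ccc(Oc2ccccc2-c2ccsc2S(=O)(=O)N2CCN(C(=O)Nc3ccc([N+](=O)[O-])cc3)CC2)cc1OC` gives > 50000 nM, which is a limit of the assay and not a number. Compound 3 `O=C(Nc1ccc([N+](=O)[O-])cc1)N1CCN(S(=O)(=O)c2sccc2-c2ccccc2Oc2ccc(O)c(O)c2)CC1` differs from compound 2 by a single change: 3,4-dihydroxyphenyl in place of 3,4-dimethoxyphenyl on an oxygen on an aromatic ring. Compound 1 also carries the 3,4-dihydroxyphenoxy group and reads 4500 nM, so a large move towards stronger inhibition is expected, with an estimated step of an at least 12-fold lower number from compound 2 to compound 3 (1.09 log units; beyond the scatter). For compound 3 the expected value is 4000 nM, with an estimated range of 1200 nM to 15000 nM.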

Compound 3, half-maximal inhibitory concentration: 4900 nM
Compound 3: the middle estimate sits 1.2-fold (0.09 log units) below what was measured; the range from low to high includes it.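

With the 4-nitrophenyl group held fixed, 3,4-dihydroxyphenyl in place of 3,4-dimethoxyphenyl on this oxygen gives an at least 10-fold lower number from compound 2 to compound 3 (1.00 log units; beyond the scatter) in this assay. Compound 2 stands at a limit of the assay, so this step is a bound and not a full size: the limit of > 50000 nM in this assay, at which 1 of the 3 values shown sits. With the 3,4-dihydroxyphenoxy group in place, 4-nitrophenyl in place of 3-nitrophenyl on the amide-type nitrogen gives a 1.1-fold higher number from compound 1 to compound 3 (0.04 log units; within the scatter), which lies within the scatter.

Open, as far as these compounds go, is whether both hydroxyl groups are needed, or whether one hydroxyl with one methoxy would serve as well. Also open, from the compounds shown here alone, is what an amine or a carboxylic acid on this ring would give.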